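The source may hold more compounds than are shown below. What is called first, only, known or untested is meant among the compounds shown, and "the series" means these compounds.

Measured in a physicochemical assay for solubility, at pH 7.4; on this read-out higher numbers stand for higher solubility and lower numbers for lower solubility:
- compound 1 `O=C(NCC1CCOCC1)c1cnc(Nc2ccc(Cl)c(Cl)c2)cc1C1CC1` gives 6 ug/mL
- compound 2 `O=C(NCC1CCOCC1)c1cnc(Nc2cc(Cl)cc(Cl)c2)cc1C1CC1` gives 7 ug/mL

Among the compounds with values here, compound 2 stands level with compound 1, the only other measured compound, as the two lie within the scatter of each other. Still unmeasured is compound 3 `COc1cccc(Nc2cc(C3CC3)c(C(=O)NCC3CCOCC3)cn2)c1`, with 3-methoxyphenyl in place of 3,5-dichlorophenyl on a nitrogen on an aromatic ring; in words, 3-methoxyphenyl in place of 3,5-dichlorophenyl on a nitrogen on an aromatic ring. Within the data shown here, the one measured step, a 1.2-fold higher number from compound 1 to compound 2 (0.07 log units; within the scatter), exchanges one dichlorophenyl for another, so it bears only weakly here, and every measured compound carries chlorine. In this assay a modest rise is nevertheless expected, estimated as a 2.9-fold higher number from compound 2 to compound 3 (0.46 log units; beyond the scatter). For compound 3 the expected value is 20 ug/mL, with an estimated range of 7 ug/mL to 60 ug/mL.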

Compound 3, solubility: 168 ug/mL
Compound 3: the middle estimate sits 8.4-fold (0.92 log units) below what was measured; measured number above the stated range.
By their numbers in this assay, from the lowest: compounds 1 and 2 (each within the scatter of the next); then compound 3.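

Replacing 3,5-dichlorophenyl with 3-methoxyphenyl on a nitrogen on an aromatic ring gives a 24-fold higher number from compound 2 to compound 3 (1.38 log units; beyond the scatter) in this assay and the matching replacement of 3,4-dichlorophenyl gives a 28-fold higher number from compound 1 to compound 3 (1.45 log units; beyond the scatter) on the same core. The group at this place can therefore move the read-out strongly, which the exchange between the two dichlorophenyl groups, within the scatter, did not show. Nothing available gives a cause for a step of this size.

Going by these compounds, whether the rise goes with the loss of chlorine or the arrival of methoxy stays open. An unsubstituted phenyl would separate the two, and a carboxylic acid or an amine on this ring would test how far the read-out can go.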